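The source may hold more compounds than are shown below. What is called first, only, known or untested is meant among the compounds shown, and "the series" means these compounds.

Compounds so far:
- compound 1 `COc1cccc(/C=C/C[C@H]2C[C@@H]([C@@H](O)c3ccccc3)CO[C@@H]2c2ccccc2)c1` gives 10900 nM
- compound 2 `O[C@@H](c1ccccc1)[C@H]1CO[C@H](c2ccccc2)[C@@H](C/C=C/c2ccccc2F)C1` gives 9730 nM
- compound 3 `O[C@@H](c1ccccc1)[C@H]1CO[C@H](c2ccccc2)[C@@H](C/C=C/c2ccncc2)C1` is not yet measured

In a functional assay on HeLa cells (Homo sapiens) for cytotoxicity, read by WST assay, with a stated time of 48 h (a higher number here means a weaker inhibitor, a lower number a stronger inhibitor), compound 2 gives 9730 nM and stands level with compound 1 within the scatter. The next change is pyridin-4-yl in place of 2-fluorophenyl on a double-bonded chain carbon bound to a double-bonded chain carbon. Among the measured compounds shown here, only one measured step bears on it, a swap at the same place: a 1.1-fold lower number from compound 1 to compound 2 (0.05 log units; within the scatter). For the measured compounds named here, no measured compound yet carries a ring with a hetero atom there, so this evidence is thin. Expected is a 1.1-fold higher number from compound 2 to compound 3 (0.05 log units; within the scatter), which means no step beyond the scatter. For compound 3 the estimated value is 11000 nM, with an expected range of 4500 nM to 27000 nM.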

Compound 3, half-maximal inhibitory concentration: > 100000 nM
Compound 3 gave a limit, no number (the forecaster's own chance of this, stated with the estimate: 15%); at least 9.0-fold (0.95 log units) between middle value and limit.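

Compound 3 gives a limit, not a number: the limit of > 100000 nM in this assay, at which 1 of the 3 values shown sits.

In this assay, the swap to pyridin-4-yl gives an at least 10-fold higher number from compound 2 to compound 3 (1.01 log units; beyond the scatter) and an at least 9.1-fold higher number from compound 1 to compound 3 (0.96 log units; beyond the scatter). This place on the chain therefore does respond to the ring it carries, although 2-fluorophenyl and 3-methoxyphenyl stood level, with a 1.1-fold lower number from compound 1 to compound 2 (0.05 log units; within the scatter); so far this rests on a single ring with a hetero atom.

Open, as far as these compounds go, is whether pyridin-3-yl, pyridin-2-yl or thiophen-2-yl at this place would behave like pyridin-4-yl. From the compounds shown here alone, the true size of the step also stays unknown.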